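The source may report more compounds than this note shows. Statements on the series, on what has been measured and on what is new or still open speak of the compounds shown alone.

Compound 2, with the structure `COc1ccc2[nH]c(C(=O)N3CC(=O)N(Cc4ccccc4)[C@@H](COC(C)(C)C)C3)cc2c1`, stands highest of the three compounds measured in a physicochemical assay for solubility, read by spectrophotometry, in phosphate buffer, with a stated time of 2 h, at pH 7.4 (a lower number here means a less soluble compound, a higher number a more soluble compound), where compound 2 gives 65500 nM. Its nearest neighbour is compound 3, with the structure `COc1ccc2[nH]c(C(=O)N3CC(=O)N(Cc4ccccc4)[C@@H](CN4CCN(c5ccc(F)cc5)CC4)C3)cc2c1`, which in this assay gives 20700 nM, a gap that lies beyond the scatter. The furthest is compound 1, with the structure `COc1cccc(CN2C(=O)CN(C(=O)c3cc4cc(OC)ccc4o3)C[C@@H]2CCc2ccccc2)c1`, which in this assay gives 4900 nM, again well beyond the scatter.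

Compound 4, with the structure `COc1ccc2[nH]c(C(=O)N3CC(=O)N(Cc4ccccc4)[C@@H](CN4CCn5cccc5C4)C3)cc2c1`, has not yet been measured. It differs from compound 2 in a single place: a group of 9 heavy atoms (7 carbon, 2 nitrogen; one five-membered aromatic ring with 1 hetero atom, one six-membered non-aromatic ring with 2 hetero atoms) in place of a group of 5 heavy atoms (4 carbon, 1 oxygen; no ring), on a saturated chain carbon bound to a saturated ring carbon. For the measured compounds named here, no step between two measured compounds of this set describes this exchange, so what can be said rests on the three values alone.

Compound 3 also carries a group containing rings and nitrogen at this position and gives 20700 nM, so a lower number than compound 2 is expected for compound 4, though the drop, a 1.9-fold lower number from compound 2 to compound 4 (0.27 log units; within the scatter), is estimated to be modest and may not exceed the scatter. On that basis compound 4 is expected to give 35000 nM in this assay, with a likely range from 12000 nM to 90000 nM.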

Compound 4, solubility: 29700 nM
Compound 4: the middle estimate sits 1.2-fold (0.07 log units) above what was measured; measured number inside the range.
By their numbers in this assay, from the lowest: compound 1; then compounds 3 and 4 (each within the scatter of the next); then compound 2.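

For the compounds shown here, replacing tert-butoxy with the group of 9 heavy atoms, on a saturated chain carbon bound to a saturated ring carbon, gives the first readable step at this position in this assay: a 2.2-fold lower number from compound 2 to compound 4 (0.34 log units; beyond the scatter). This shows that a group with one five-membered aromatic ring and one six-membered non-aromatic ring can stand in this place with a modest change in the number, though one that lies beyond the scatter. Compound 3 at 20700 nM and compound 4 at 29700 nM lie within the scatter of each other, so these two ring-bearing groups with nitrogen cannot be told apart in this assay, and no measurement bears on what lies behind the step.

The leaving and entering groups differ in size, atoms and rings all at once, so the compounds shown do not separate which of these features goes with the lower number. Nor do they show how an open-chain amine such as dimethylamino, a carboxylic acid or a longer carbon chain at this position would compare with tert-butoxy.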